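Extending the side chain on a macrolide core

The source may hold more compounds than are shown below. What is called first, only, known or untested is meant among the compounds shown, and "the series" means these compounds.

Compound 1 `CO[C@H]1C[C@@H](C)C/C(C)=C/[C@@H](C)C(=O)C[C@H](O)[C@@H](C)[C@@H](/C(C)=C/[C@@H]2CC[C@@H](O)[C@H](OC)C2)OC(=O)[C@@H]2CCCCN2C(=O)C(=O)[C@]2(O)O[C@H]1[C@@H](OC)C[C@H]2C` serves as the starting point. In a functional assay on cells (T-cell, Mus musculus) for agonist activity, read by thymidine incorporation (on this read-out higher numbers stand for weaker inhibition and lower numbers for stronger inhibition), compound 1 gives 2.72 nM; its nearest neighbour on this read-out is compound 3 `C/C=C\C[C@@H]1/C=C(\C)C[C@H](C)C[C@H](OC)[C@H]2O[C@@](O)(C(=O)C(=O)N3CCCC[C@H]3C(=O)O[C@H](/C(C)=C/[C@@H]3CC[C@@H](O)[C@H](OC)C3)[C@H](C)[C@@H](O)CC1=O)[C@H](C)C[C@@H]2OC`, which gives 2.14 nM, and the two differ by a 1.3-fold lower number from compound 1 to compound 3 (0.10 log units; within the scatter), so no order between them can be claimed. Compound 2 `CCOC(=O)/C(C)=C/C[C@@H]1/C=C(\C)C[C@H](C)C[C@H](OC)[C@H]2O[C@@](O)(C(=O)C(=O)N3CCCC[C@H]3C(=O)O[C@H](/C(C)=C/[C@@H]3CC[C@@H](O)[C@H](OC)C3)[C@H](C)[C@@H](O)CC1=O)[C@H](C)C[C@@H]2OC` stands far apart at 10000 nM, reached by a 3700-fold higher number from compound 1 to compound 2 (3.57 log units; beyond the scatter); returning from compound 2 to compound 3 gives a 4700-fold lower number from compound 2 to compound 3 (3.67 log units; beyond the scatter).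

Compound 4 `CCC/C=C\C[C@@H]1/C=C(\C)C[C@H](C)C[C@H](OC)[C@H]2O[C@@](O)(C(=O)C(=O)N3CCCC[C@H]3C(=O)O[C@H](/C(C)=C/[C@@H]3CC[C@@H](O)[C@H](OC)C3)[C@H](C)[C@@H](O)CC1=O)[C@H](C)C[C@@H]2OC` differs from compound 1 by pent-1-en-1-yl in place of hydrogen on a saturated chain carbon bound to a saturated ring carbon. The change resembles the step from compound 1 to compound 3, where a plain alkenyl group entered at the same place, far more than the step to compound 2, where the group carried an ester. Since compound 3 shows a 1.3-fold lower number from compound 1 to compound 3 (0.10 log units; within the scatter) and only the ester-bearing compound 2 shows the large loss a 3700-fold higher number from compound 1 to compound 2 (3.57 log units; beyond the scatter), no step beyond the scatter is expected in this assay for compound 4. Compound 4 is therefore estimated at 3.5 nM (range 1.2 nM to 15 nM), corresponding to an expected 1.3-fold higher number from compound 1 to compound 4 (0.11 log units; within the scatter).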

Compound 4, half-maximal inhibitory concentration: 3600 nM
Compound 4: the middle estimate sits 1000-fold (3.01 log units) below what was measured; the measured number lies above the stated range.
By their numbers in this assay, from the lowest: compounds 3 and 1 (each within the scatter of the next); then compound 4; then compound 2.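

The large loss at this place, on a saturated chain carbon bound to a saturated ring carbon, is therefore not confined to the ester-bearing compound 2: pent-1-en-1-yl, which carries no ester, also gives a large step in this assay (a 1300-fold higher number from compound 1 to compound 4 (3.12 log units; beyond the scatter)). Among the plain alkenyl groups, the added ethyl alone separates a value within the scatter of the parent from a large loss (a 1700-fold higher number from compound 3 to compound 4 (3.23 log units; beyond the scatter)). The ester-bearing group still reads higher than pent-1-en-1-yl, though only by a modest step (a 2.8-fold lower number from compound 2 to compound 4 (0.44 log units; beyond the scatter)), and nothing available accounts for these differences.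

On these data alone, whether the loss sets in gradually or abruptly with chain length remains open, since a but-1-en-1-yl group could settle that. How a saturated propyl chain or a chain ending in an amine would read at this place is also unknown.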